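The source may hold more compounds than are shown below. What is called first, only, known or untested is meant among the compounds shown, and "the series" means these compounds.

The study brings together three measured compounds and one that still awaits testing, all judged in a functional assay on CCRF-CEM cells (Homo sapiens) for cytotoxicity, read by MTT assay, with a stated time of 72 h; on this read-out lower numbers stand for stronger inhibition of growth and higher numbers for weaker inhibition of growth. Compound 1 `CSc1ccc(CNc2nc(SC)nc3ncccc23)cc1` gives 5350 nM in this assay. Compound 2 `CCCCC[Se]c1nc(N)c2ccccc2n1` gives 34800 nM in this assay, which is the higher of the two numbers recorded so far, its gap to compound 1 lying beyond the usual scatter of such measurements. Compound 3 `COc1ccc(CNc2nc([SeH])nc3ccccc23)cc1` yields only a limit of the assay in this assay, reported as > 100000 nM, and this matches (the limit of > 100000 nM in this assay, at which 1 of the 3 values shown sits).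

The account now turns to compound 4 `C[Se]c1nc(N)c2ccccc2n1`, which has not yet been measured. Set against compound 2, the difference is hydrogen in place of butyl on a saturated chain carbon bound to a selenium atom. No measured pair among these compounds differs in this way, so nothing in the recorded numbers shows how far such a shortening moves the read-out. The step from compound 2 to compound 4 is therefore expected to be modest, a 1.1-fold higher number from compound 2 to compound 4 (0.06 log units; within the scatter), most likely within the scatter of repeated measurements, with no firm direction. Compound 4 is accordingly estimated to give 40000 nM in this assay, with a plausible range from 10000 nM to 150000 nM, and with some chance that only a limit is returned, as happened for compound 3.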

Compound 4, concentration for 50% growth inhibition: 65100 nM
The estimate for compound 4 lay 1.6-fold (0.21 log units) below the measured number; measured number inside the range.
By their numbers in this assay, from the lowest: compound 1; then compounds 2 and 4 (each within the scatter of the next). At a limit, above all of these: compound 3.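

This is the first pair among the compounds shown that differs only in one place, with hydrogen in place of butyl on a saturated chain carbon bound to a selenium atom, and in this assay the result is a 1.9-fold higher number from compound 2 to compound 4 (0.27 log units; within the scatter). For this pair, then, going from pentyl to methyl on the selenium does not separate the two compounds by more than repeated measurements would, so in this read-out the full length of the pentyl chain is not shown to matter. Nothing recorded here accounts for this outcome, and no measured property of either compound bears on it.

A single pair cannot show whether the same holds across other groups at this place, and a longer chain such as octyl, a benzyl group or a chain ending in an amine could still give a clearly different number. It also remains open whether a change at this place would have the same size on a different core, since no other pair among the compounds shown carries it.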